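Adding chloro to compound 1: expected stability

The source may hold more compounds than are shown below. What is called first, only, known or untested is meant among the compounds shown, and "the series" means these compounds.

Measured so far:
compound 1 `COC(=O)Nc1cc(-c2ccc(OC[C@@](C)(N)CC(C)C)cn2)ccn1` gives 93% remaining
compound 2 `CC(=O)Nc1cc(-c2ccc(OC[C@@H](N)CC(C)C)c(C)c2)ccn1` gives 64% remaining
compound 3 `COC(=O)Nc1cc(-c2ccc(OC[C@@](C)(N)CC(C)C)c(Cl)n2)ccn1` gives 72% remaining

In an ADME assay on microsomes from liver (Mus musculus) for metabolic stability, read by LC-MS, using NADPH, with a stated time of 10 min, tested at 0.5 uM (on this read-out higher numbers stand for a more stable compound and lower numbers for a less stable compound), compound 1 stands highest of the three measured compounds, with 93% remaining. Compound 3 lies nearest to it and compound 2 furthest, both with numbers lower than compound 1 by more than the scatter.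

The next compound is compound 4 `COC(=O)Nc1cc(-c2cc(Cl)c(OC[C@@](C)(N)CC(C)C)cn2)ccn1`, not yet measured. The structural change is chloro in place of hydrogen on an aromatic carbon in which chloro takes the place of hydrogen on an aromatic carbon, ortho to the (2-amino-2,4-dimethylpentyl)oxy group and opposite the ring nitrogen.

For the measured compounds named here, one measured step bears on this change. It is also chloro in place of hydrogen on an aromatic carbon, though not on the same carbon, and it gave a number 21 percentage points lower from compound 1 to compound 3 (beyond the scatter) in the same read-out. A single step at another carbon is a weak guide, and the data hold no measurement at the carbon concerned. A drop of modest size is therefore expected, probably somewhat smaller than that one, and a result within the scatter of compound 1 remains possible.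

The estimated step is a number 16 percentage points lower from compound 1 to compound 4 (beyond the scatter) on this reading. For compound 4 the expected value is 77% with an estimated range from 60% to 92% in this assay when measured.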

Compound 4, percent of the compound remaining: 87%
Compound 4: middle estimate off by 10 percentage points, on the low side, within the range that was stated.
By their numbers in this assay, from the lowest: compounds 2 and 3 (each within the scatter of the next); then compounds 4 and 1 (each within the scatter of the next).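

In this assay, chloro on the aromatic carbon ortho to the (2-amino-2,4-dimethylpentyl)oxy group and opposite the ring nitrogen is tolerated on the core of compound 1, with a step of a number 6 percentage points lower from compound 1 to compound 4 (within the scatter). The same replacement of hydrogen by chloro therefore does not give one outcome across this ring: at the other carbon, the step was a number 21 percentage points lower from compound 1 to compound 3 (beyond the scatter), so the outcome in this pair depends on the carbon that carries the chloro. Nothing measured here accounts for the contrast between the two carbons.

The compounds shown leave open whether this carbon accepts substituents other than chloro, such as fluoro, methoxy or nitrile, since a single step with a single atom says little about larger or differently built groups. Also open, as far as these compounds go, is whether the tolerance for chloro at this carbon carries over when the (2-amino-2,4-dimethylpentyl)oxy group is replaced by a longer chain or the amine on it by a carboxylic acid.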